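This account rests on a few compounds, and the source may have more. Where it says the series, first, only, none or still open, it means among the compounds named here.

In a functional assay on the whole organism (strain albino) for inhibition, with Rattus norvegicus as the target, read by paw edema, with a stated time of 3 h, at a dose of 0.28 mmol/kg by the oral route (a higher number here means more inhibition at the dose given (going by the name of the read-out), a lower number less inhibition), compound 1 `C=CCn1c(SCC(=O)c2ccccc2)nnc1-c1ccc(OC)c(OC)c1` gives 64%, and compound 2 `C=CCn1c(SCC(=O)c2ccccc2)nnc1-c1ccc(OC)cc1` gives 63%. Compound 2 arises from compound 1 by hydrogen in place of methoxy on an aromatic carbon, and this made a number 1 percentage points lower from compound 1 to compound 2 (within the scatter). Compound 3 `CCn1c(SC/C(=N/O)c2ccccc2)nnc1-c1cc(OC)c(OC)c(OC)c1` gives 69% in this assay; the difference between the core of compound 3 and the core of compound 1 is not broken down here. Compound 4 `CCn1c(SC/C(=N/O)c2ccccc2)nnc1-c1ccc(OC)c(OC)c1` has not yet been measured in this assay. It arises from compound 3 by hydrogen in place of methoxy on an aromatic carbon, the same kind of change as that from compound 1 to compound 2, though here the place is also meta to a methoxy group. Because the step of a number 1 percentage points lower from compound 1 to compound 2 (within the scatter) stayed within the scatter, compound 4 is expected to give 67%, with a range from 56% to 77%. The step of a number 2 percentage points lower from compound 3 to compound 4 (within the scatter) is therefore expected to be small.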

Compound 4, a percentage reported as inhibition, in the whole organism at one dose (the size of the read-out at that dose, not a potency): 71%
For compound 4 the middle estimate is 4 percentage points below the measured one; low and high end bracket the measured number.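

In this assay, hydrogen in place of methoxy on an aromatic carbon gave a number 2 percentage points higher from compound 3 to compound 4 (within the scatter). Set beside the earlier step, the change carried from one core to the other without a difference that can be told apart: the same change on two cores in this assay, a number 1 percentage points lower (within the scatter) from compound 1 to compound 2 and a number 2 percentage points higher (within the scatter) from compound 3 to compound 4, 3 percentage points apart, within the scatter of two such steps This shows that the change stayed small on these two cores at this one oral dose and time, but it does not show that it would stay small on any other core, and two pairs are too few to support a rule for the series.

The compounds shown leave open what an amine, a carboxylic acid or a longer chain would give in place of the methoxy group.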